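A few compounds are considered here, and "the series" means these few. Any claim that something is new, unique, unknown or untested is made for them only; others in the source may bear on it.

Measured compounds:
Compound 1, `CN1CCN(C(=O)Cn2c(-c3ccccc3)csc2=N)CC1` — in an assay on isolated protein for inhibition of leukotriene A-4 hydrolase (Homo sapiens) (a higher number here means a weaker inhibitor, a lower number a stronger inhibitor), compound 1 gives 629 nM.
Compound 2, `N=c1scc(-c2ccccc2)n1CC(=O)N1CCN(c2ccccc2)CC1` — in this assay compound 2 gives 643 nM.

Of the two numbers shown, compound 1 holds the lowest, yet the gap to compound 2 is within the scatter: the step of a 1.0-fold higher number from compound 1 to compound 2 (0.01 log units; within the scatter) is as small as a repeat measurement might give. That step swaps the group on the ring amine nitrogen at the far end of the amide.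

Compound 3, `N=c1scc(-c2ccccc2)n1CC(=O)N1CCOCC1`, is not yet measured. It differs from compound 1 at the same end of the molecule: morpholin-4-yl in place of 4-methylpiperazin-1-yl on a carbonyl carbon. Within the data shown here, the one measured step that bears on this place, a 1.0-fold higher number from compound 1 to compound 2 (0.01 log units; within the scatter), shows that exchanging the substituent on that ring nitrogen left the inhibition constant unchanged beyond the scatter. Removing the methylated nitrogen altogether in favour of a ring oxygen is a different kind of change, so the two compounds give only a loose guide. Compound 3 is therefore expected to show a step of a 1.2-fold higher number from compound 1 to compound 3 (0.08 log units; within the scatter) that stays within or near the scatter. The estimate for compound 3 is 750 nM, with a range from 300 nM to 1900 nM.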

Compound 3, inhibition constant: 8650 nM
Estimate against measurement, compound 3: 12-fold (1.06 log units) below; measured number above the stated range.
By their numbers in this assay, from the lowest: compounds 1 and 2 (each within the scatter of the next); then compound 3.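

In this assay, the group on the carbonyl carbon proves not to be indifferent: with morpholin-4-yl in place of 4-methylpiperazin-1-yl, the result is a 14-fold higher number from compound 1 to compound 3 (1.14 log units; beyond the scatter). The earlier step, a 1.0-fold higher number from compound 1 to compound 2 (0.01 log units; within the scatter), had changed only the group on the ring amine nitrogen, so it could not show what happens when that nitrogen itself is replaced by a ring oxygen; this replacement is what separates compound 3 from compound 1, although both groups are six-membered non-aromatic rings with matching counts of hydrogen-bond donors and acceptors. Nothing available on these compounds accounts for the size of this step.

The compounds shown leave open whether the ring nitrogen is itself what matters, since a piperidin-1-yl group, with a ring carbon at that point, or an unsubstituted piperazin-1-yl group could fall with either compound 1 or compound 3. They also leave open whether an open-chain amine such as dimethylamino on the carbonyl carbon would keep the number of compound 1, and whether the step would be the same with another group in place of the phenyl on the shared core.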